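From acetyl to benzoyl on a shared core

The source may hold more compounds than are shown below. What is called first, only, known or untested is meant among the compounds shown, and "the series" means these compounds.

In an ADME assay on Vero cells (Chlorocebus sabaeus) for cytotoxicity, read by trypan blue exclusion, with a stated time of 24 h (on this read-out higher numbers stand for weaker inhibition and lower numbers for stronger inhibition), compound 2 (`COc1cc(C[C@@H](C)[C@@H](C)Cc2ccc(OC(C)=O)c(OC)c2)ccc1O`) gives 112 ug/mL, the highest of three numbers, although compound 1 (`COc1cc(C[C@@H](C)[C@@H](C)Cc2ccc(OC(=O)c3cccnc3)c(OC)c2)ccc1O`) at 71.4 ug/mL cannot be told apart from it. Compound 3 (`COc1cc(C[C@@H](C)[C@@H](C)Cc2ccc(OC(=O)c3cccnc3)c(OC)c2)ccc1OC(=O)c1cccnc1`) gives 36.3 ug/mL, beyond the scatter from compound 2. Compound 4 (`COc1cc(C[C@@H](C)[C@@H](C)Cc2ccc(OC(=O)c3ccccc3)c(OC)c2)ccc1O`) is not yet measured and differs from compound 2 by phenyl in place of methyl on a carbonyl carbon. The closest evidence is the matching swap at the same carbonyl carbon, a 1.6-fold higher number from compound 1 to compound 2 (0.20 log units; within the scatter). The other measured change, a 2.0-fold lower number from compound 1 to compound 3 (0.29 log units; within the scatter), lies elsewhere on the molecule and bears on it only loosely. In this assay the expected result is therefore no change beyond the scatter, perhaps slightly lower, an estimated 1.4-fold lower number from compound 2 to compound 4 (0.16 log units; within the scatter). For compound 4 the estimate is 78 ug/mL, with an expected range of 40 ug/mL to 140 ug/mL.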

Compound 4, half-maximal inhibitory concentration: 125 ug/mL
Compound 4: middle estimate off by 1.6-fold (0.20 log units), on the low side, and the stated range covers the measured number.
By their numbers in this assay, from the lowest: compounds 3, 1, 2 and 4 (each within the scatter of the next, the first and the last beyond it).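

In this assay, phenyl in place of methyl on this carbonyl carbon adds a six-membered aromatic ring, yet the result is a 1.1-fold higher number from compound 2 to compound 4 (0.05 log units; within the scatter). Phenyl in place of pyridin-3-yl gives a 1.8-fold higher number from compound 1 to compound 4 (0.24 log units; within the scatter), so methyl, pyridin-3-yl and phenyl at this place all lie within the scatter of one another. No measurement shown here accounts for this. On these data alone, what remains open is whether a phenyl ring carrying an amine or a carboxylic acid, or a longer chain in place of phenyl, would shift the number beyond the scatter.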